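Three Diaryl Ureas Compared, A Fourth Awaited

The source may report more compounds than this note shows. Statements on the series, on what has been measured and on what is new or still open speak of the compounds shown alone.

Measured compounds:
compound 1, `COc1cc(NC(=O)Nc2cc(Nc3cccc(C(C)(C)C)c3)ncn2)cc(OC)c1`, 40%
compound 2, `COc1cc(NC(=O)Nc2cc(Nc3cc(C)cc(F)c3)ncn2)cc(OC)c1`, 35.3%
compound 3, `COc1cc(NC(=O)Nc2cc(Nc3ccc(OC)c(I)c3)ncn2)cc(OC)c1`, 40.1%

The three measured compounds share one core and differ only in the aryl group on a nitrogen on an aromatic ring. In a functional assay on NCI-H226 cells (Homo sapiens) for inhibition, read by MTT assay, with a stated time of 48 h, tested at 10 uM (on this read-out lower numbers stand for less inhibition and higher numbers for more inhibition at the one concentration tested (going by the name of the read-out)), compound 1 gives 40%, compound 2 gives 35.3% and compound 3 gives 40.1%. Compound 3 has the highest of the three numbers, yet its steps to both neighbours are small: a number 0.1 percentage points higher from compound 1 to compound 3 (within the scatter) and a number 4.8 percentage points higher from compound 2 to compound 3 (within the scatter), and the third step, a number 4.7 percentage points lower from compound 1 to compound 2 (within the scatter), is likewise within the scatter. No change of aryl group among these three moved the read-out beyond noise.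

Compound 4, `COc1cc(NC(=O)Nc2cc(Nc3ccc(F)c(Cl)c3)ncn2)cc(OC)c1`, carries 3-chloro-4-fluorophenyl in place of 3-iodo-4-methoxyphenyl on a nitrogen on an aromatic ring. All three measured steps bear on it, since each swaps one aryl group for another at the same place, and none left the scatter. The expected step is therefore small: a number 2.1 percentage points lower from compound 3 to compound 4 (within the scatter), none beyond the scatter. Compound 4 is estimated at 38%, between 26% and 50%.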

Compound 4, a percentage reported as inhibition, at one concentration (the size of the read-out at that concentration, not a potency): 36.7%
Estimate against measurement, compound 4: 1.3 percentage points above; measured number inside the range.
By their numbers in this assay, from the lowest: compounds 2, 4, 1 and 3 (each within the scatter of the next).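

Replacing 3-iodo-4-methoxyphenyl with 3-chloro-4-fluorophenyl on a nitrogen on an aromatic ring removes the hydrogen-bond acceptor counted in the leaving group and gives, in this assay, a number 3.4 percentage points lower from compound 3 to compound 4 (within the scatter). The other two new comparisons agree, with a number 1.4 percentage points higher from compound 2 to compound 4 (within the scatter) and a number 3.3 percentage points lower from compound 1 to compound 4 (within the scatter), so all four aryl groups now seen at this position, including this one with two halogens and no oxygen, stay within the scatter of one another. No measurement shown here offers an explanation for this flat result.

Every group shown at this position is a substituted phenyl ring, so it remains open whether a carboxylic acid or a morpholine on that ring would move the read-out beyond the scatter. As far as these compounds go, it also remains open whether these four compounds would separate at other concentrations.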